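Swapping Hydroxy for Methyl on the Aryl Ring

This account rests on a few compounds, and the source may have more. Where it says the series, first, only, none or still open, it means among the compounds named here.

Of the compounds shown here, three sharing one core have been measured in a functional assay on HepG2 cells (Homo sapiens) for inhibition, read by MTT assay, with a stated time of 72 h; a higher number here means a weaker inhibitor, a lower number a stronger inhibitor. Compound 1 `COc1cc(O)c(CC=C(C)C)c(O)c1C(=O)/C=C/c1ccc(Cl)cc1` gives 10100 nM, and compound 2 `COc1cc(O)c(CC=C(C)C)c(O)c1C(=O)/C=C/c1ccc([N+](=O)[O-])cc1` gives 12400 nM; the step of a 1.2-fold higher number from compound 1 to compound 2 (0.09 log units; within the scatter) lies within the scatter. Compound 3 `COc1cc(O)cc(O)c1C(=O)/C=C/c1ccc(O)cc1`, which lacks the prenyl chain of the other two and carries a hydroxy on the far ring, gives 40200 nM, the highest of the three numbers.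

Compound 4 `COc1cc(O)cc(O)c1C(=O)/C=C/c1ccc(C)cc1` differs from compound 3 in one place: methyl in place of hydroxy on an aromatic carbon. Within the data shown here, no measured step addresses this change. Among the measured compounds shown here, the only step on hand, from chloro to nitro, lies within the scatter and says nothing about a hydroxy leaving. Compounds 1 and 2 give lower numbers than compound 3 while bearing no hydroxy on that ring, but each differs from compound 3 in more than one place, so their values cannot be read as a step for this change alone.

With so little to lean on, compound 4 is expected to stay near compound 3, with at most a small drift toward a lower number, expected as a 1.4-fold lower number from compound 3 to compound 4 (0.16 log units; within the scatter). The estimate for compound 4 in this assay is therefore 28000 nM, expected to fall between 10000 nM and 80000 nM.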

Compound 4, half-maximal inhibitory concentration: > 50000 nM
Compound 4: a limit, no number; the forecaster's own chance of this, stated with the estimate: 10%; at least 1.7-fold (0.25 log units) between middle value and limit.
By their numbers in this assay, from the lowest: compounds 1 and 2 (each within the scatter of the next); then compound 3. At a limit, above all of these: compound 4.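

In this assay compound 4 gives > 50000 nM, which is a limit of the assay and not a number. Among these compounds, putting 4-methylphenyl where 4-hydroxyphenyl stood gives an at least 1.2-fold higher number from compound 3 to compound 4 (0.09 log units; that floor lies within the scatter), the first direct reading of a hydroxy leaving this aromatic carbon, which the earlier chloro-to-nitro step could not supply, and it shows no move toward a lower number with methyl in its place. How large the rise is remains unfixed, and the printed floor of the step cannot settle whether this change matters beyond the scatter, as compound 4 alone among the compounds shown stands at such a limit: the limit of > 50000 nM in this assay, at which 1 of the 4 values shown sits.

The compounds shown leave open whether another group on this aromatic carbon, such as an amine or a carboxylic acid, would hold the number near that of compound 3 or carry it lower. Also open is whether the same swap of hydroxy for methyl reads alike on a core bearing the prenyl chain of compound 1, as no pair shown differs in that one place on such a core.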